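The compounds below may be only part of what the source reports. "The series", "measured", "known", "first", "only" and "open" are said of these compounds alone.

Compound 3, with the structure `Cc1nnc(-c2cccc(-c3ccc(C(=O)N(Cc4cccc(OCCCCCC(=O)O)c4)C(C)C)cc3)c2)o1`, was tested in an ADME assay on BJ cells (Homo sapiens) for cytotoxicity, read by CellTiter-Glo and resazurin assay, with a stated time of 72 h; a lower number here means that less compound is needed, a higher number that more compound is needed for the effect. In this assay compound 3 gives only a limit, > 26000 nM. Two related compounds were measured the same way. Compound 1, `CC(C)N(Cc1cccc(OCCCCCC(=O)O)c1)C(=O)c1ccc(-c2ccncc2)cc1`, also gives only a limit in this assay, namely > 26000 nM. Compound 2, `CC(C)N(Cc1cccc(OCCCCCC(=O)O)c1)C(=O)c1ccc(-c2ccsc2)cc1`, likewise gives only a limit in this assay, > 26000 nM. Since every value shown is a limit, none of the steps among these compounds can be read: the step that the two limits leave unreadable from compound 1 to compound 2, the step that the two limits leave unreadable from compound 1 to compound 3 and the step that the two limits leave unreadable from compound 2 to compound 3 all remain of unknown size, and the single fact available is the limit of > 26000 nM in this assay, at which 3 of the 3 values shown sit.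

The next compound, compound 4, has the structure `CC(C)N(Cc1cccc(OCCCCCC(=O)O)c1)C(=O)c1ccc(-c2cccc(OC(F)(F)F)c2)cc1`. It differs from compound 3 in one place: trifluoromethoxy in place of 5-methyl-1,3,4-oxadiazol-2-yl on an aromatic carbon. Among the measured compounds shown here, none of the measured steps can tell how such a change bears on this assay, so no direction and no size beyond the scatter can be expected from them. The estimate for compound 4 therefore rests on the limits alone: the step that the limit leaves unreadable from compound 3 to compound 4 is expected to be close to nothing, and compound 4 is estimated to sit around 30000 nM in this assay, within a range from 9000 nM to 90000 nM, most likely again reported only as a limit.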

Compound 4, half-maximal effective concentration: > 26000 nM
Compound 4 was reported as a limit (the forecaster's own chance of this, stated with the estimate: 70%); the middle value lies beyond the limit too.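

In this assay compound 4 gives > 26000 nM, which is a limit and not a number. The steps linking compound 4 with compound 1, compound 2 and compound 3 therefore cannot be read, and one fact remains: the limit of > 26000 nM in this assay, at which 4 of the 4 values shown sit. The compounds shown leave open whether any of these groups changes the amount of compound needed in this assay, and by how much.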